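Hexyl for hydrogen on the shared core: cytotoxicity note

This account rests on a few compounds, and the source may have more. Where it says the series, first, only, none or still open, it means among the compounds named here.

Compound 1 `O=c1c2c(C(F)(F)F)cc(-c3ccccc3)nc2ncn1Cc1cn(CCC(F)(F)C(F)(F)C(F)(F)C(F)(F)C(F)(F)C(F)(F)C(F)(F)C(F)(F)F)nn1` is assessed in a functional assay on THP-1 cells (Homo sapiens) for cytotoxicity, read by MTT assay, with a stated time of 24 h (on this read-out lower numbers stand for stronger inhibition and higher numbers for weaker inhibition), where compound 1 gives 79.1 ug/mL. Compound 2 `CCCCCCCCCCn1cc(Cn2c(CC)nc3nc(-c4ccccc4)cc(C(F)(F)F)c3c2=O)nn1`, which carries an ethyl at the same position of the core and a decyl chain on the triazole, gives 82.7 ug/mL in this assay; the two numbers sit within the usual scatter of each other, so no order between compound 1 and compound 2 can be read from them. Among the measured compounds shown here, no single-change step between measured compounds is available.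

Compound 3 `CCCCCCc1nc2nc(-c3ccccc3)cc(C(F)(F)F)c2c(=O)n1Cc1cn(CCC(F)(F)C(F)(F)C(F)(F)C(F)(F)C(F)(F)C(F)(F)C(F)(F)C(F)(F)F)nn1` differs from compound 1 by hexyl in place of hydrogen on an aromatic carbon. For the measured compounds named here, the only related comparison, compound 1 against compound 2, shows no movement beyond the scatter when an alkyl chain occupies this position, though that pair also differs on the triazole substituent, so it is not a clean guide.

The step from compound 1 to compound 3 is therefore expected to be small, most likely within the scatter, with any drift toward a lower number: a 1.2-fold lower number from compound 1 to compound 3 (0.09 log units; within the scatter). Compound 3 is estimated to give 65 ug/mL in this assay, expected between 30 ug/mL and 130 ug/mL.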

Compound 3, half-maximal inhibitory concentration: > 200 ug/mL
Compound 3: a limit, no number; the forecaster's own chance of this, stated with the estimate: 10%; middle value at least 3.0-fold (0.48 log units) from the limit.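

Hexyl in place of hydrogen on an aromatic carbon, between two ring nitrogen atoms, gives the first single-change step of the series in this assay: an at least 2.5-fold higher number from compound 1 to compound 3 (0.40 log units; beyond the scatter). This shows that the position is not indifferent to substitution on the core of compound 1, and that a hexyl chain here moves the read-out beyond the scatter towards weaker inhibition. Compound 3 gives > 200 ug/mL, which is a limit of the assay and not a number, so the step is bounded on one side only and its full size stays unknown: the limit of > 200 ug/mL in this assay, at which 1 of the 3 values shown sits.

The compounds shown leave open whether the shift belongs to the length of the chain or to any substituent at this position, and a methyl or an amine on the same carbon would help to separate the two. They also leave open whether the step carries over to the decyl chain on the triazole of compound 2, since its counterpart with hydrogen at this position is not among them.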